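From methoxy to chloro in compound 4

This account rests on a few compounds, and the source may have more. Where it says the series, first, only, none or still open, it means among the compounds named here.

- compound 1 `COc1cc(C(=O)c2sc(N(C)C)nc2N)cc(OC)c1OC` gives 11000 nM
- compound 2 `COc1ccc(C(=O)c2sc(N3CCCC3)nc2N)cc1OC` gives 19000 nM
- compound 3 `COc1ccc(C(=O)c2sc(N3CCCC3)nc2N)cc1` gives > 200000 nM (a limit)

All three compounds were read in a functional assay on CCRF-CEM cells (Homo sapiens) for antiproliferative activity, read by cell counting, with a stated time of 2 days (a higher number here means a weaker inhibitor, a lower number a stronger inhibitor), and share one core. Compound 1 and compound 2 lie within the scatter of each other. Compound 3 has only a limit and not a number (the limit of > 200000 nM in this assay, at which 1 of the 3 values shown sits).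

Compound 4 `Nc1nc(N2CCCC2)sc1C(=O)c1ccc(Cl)cc1` carries chloro in place of methoxy (chloro in place of methoxy on an aromatic carbon) on an aromatic carbon of the six-membered aromatic ring of carbon only, para to a large group. For the measured compounds named here, one measured step bears on this change, and only indirectly. Hydrogen in place of methoxy on an aromatic carbon gave an at least 10-fold higher number from compound 2 to compound 3 (1.02 log units; beyond the scatter) and that large step concerned a different methoxy, since compound 3 still keeps the one now exchanged. Going by the values given here, no measured step replaces a methoxy by chloro, so no recovery can be read from the data, and no clear change is expected in this assay on this evidence. The expected step is an at least 1.3-fold lower number from compound 3 to compound 4 (0.12 log units; that floor lies within the scatter) and that lies within the scatter. For compound 4 the estimated value is 150000 nM with an expected range from 50000 nM to 400000 nM and the assay may well report only a limit again.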

Compound 4, half-maximal inhibitory concentration: > 200000 nM
Compound 4: no number, only a limit; the forecaster's own chance of this, stated with the estimate: 60%; middle value at least 1.3-fold (0.12 log units) away from the limit.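

In this assay compound 4 gives > 200000 nM, a limit and not a number. For the compounds shown here, compound 3 gave the same limit, so no step between compound 3 and compound 4 can be read: the limit of > 200000 nM in this assay, at which 2 of the 4 values shown sit. The compounds shown leave open whether chloro in place of methoxy on an aromatic carbon changes the antiproliferative activity at all.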